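This account rests on a few compounds, and the source may have more. Where it says the series, first, only, none or still open, it means among the compounds named here.

Measured in a functional assay on HT-29 cells (Homo sapiens) for antiproliferative activity, read by XTT assay, with a stated time of 72 h; on this read-out higher numbers stand for weaker inhibition and lower numbers for stronger inhibition:
- compound 1 `C=C(C)CC[C@]1(C)C2=CCC[C@](C)(C[C@H](O)c3ccoc3)[C@H]2CC[C@H]1C`: 30000 nM
- compound 2 `C=C(C)CCC[C@]1(C)C2=CCC[C@](C)(C[C@@H](O)C3=CC(=O)OC3O)[C@H]2CC[C@H]1C`: 2300 nM
- compound 3 `C=C(C)CCC[C@]1(C)C2=CCC[C@](C)(C[C@@H](O)c3ccoc3)[C@H]2CC[C@H]1C`: 63100 nM

Compound 3 carries the highest number of the three, and compound 1 is its nearest neighbour. Compound 4 `C=C(C)CCC[C@]1(C)C2=CCC[C@](C)(C[C@H](O)c3ccoc3)[C@H]2CC[C@H]1C` is the next entry, and its relation to compound 3 is simple: the two compounds have the same atoms and bonds and differ only in configuration as drawn: 1 of 5 stereo elements differ; a stereocentre at a saturated chain carbon is drawn R in compound 3 and S in compound 4.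

For the measured compounds named here, only one measured step links two compounds that differ in one place, a 27-fold higher number from compound 2 to compound 3 (1.44 log units; beyond the scatter). That step is large, but it exchanges one group for another and leaves configuration untouched, so its size does not carry over. Going by the values given here, no measured step isolates a change of configuration. Compound 1, which also bears the five-membered aromatic ring, gives 30000 nM, so the values with this ring stay high. A step beyond the scatter is therefore not expected, and no direction can be argued with confidence. The expected change is small: a 1.4-fold lower number from compound 3 to compound 4 (0.15 log units; within the scatter). For compound 4 the estimated value is 45000 nM, with an expected range of 18000 nM to 110000 nM.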

Compound 4, half-maximal inhibitory concentration: 63100 nM
Compound 4: the middle estimate sits 1.4-fold (0.15 log units) below what was measured, within the range that was stated.
By their numbers in this assay, from the lowest: compound 2; then compound 1; then compounds 3 and 4 (each within the scatter of the next).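

In this assay, for the compounds shown here, the drawn configuration at this saturated chain carbon is now isolated for the first time, and the step is no change at the digits printed from compound 3 to compound 4 (within the scatter), so with the five-membered aromatic ring in place this stereocentre leaves the read-out within the scatter, the comparison being a clean one: the fact that compounds 3 and 4 differ only in the configuration as drawn.
The large step on leaving the five-membered non-aromatic ring of compound 2 holds with either drawn configuration, at a 27-fold higher number from compound 2 to compound 4 (1.44 log units; beyond the scatter) beside the earlier 27-fold higher number from compound 2 to compound 3 (1.44 log units; beyond the scatter).
The chain change also gains a clean reading, 2-methylprop-2-en-1-yl in place of 1-methylethenyl, as a 2.1-fold higher number from compound 1 to compound 4 (0.32 log units; beyond the scatter).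

From the compounds shown here alone, whether configuration is equally silent with the non-aromatic ring of compound 2 stays open. Also open, going by these compounds, is how an amine or a carboxylic acid on this saturated chain carbon would read.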